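Chlorophenyl variation on the diacylhydrazine amide carbonyl

The compounds below may be only part of what the source reports. "The series", "measured", "known", "first", "only" and "open" are said of these compounds alone.

Compound 1 `CC(C)(C)N(NC(=O)c1cccc(Cl)c1)C(=O)c1ccccc1Cl` gives 155 nM in an assay on cells for agonist activity at ecdysone receptor (Bombyx mori), read by a luciferase reporter, with a stated time of 24 h; on this read-out lower numbers stand for an effect already at smaller amounts and higher numbers for an effect only at larger amounts of compound. Compound 2 `COc1cccc(C(=O)NN(C(=O)c2ccccc2Cl)C(C)(C)C)c1` gives 52.5 nM, and compound 3 `CC(C)(C)N(NC(=O)c1ccc(Cl)cc1)C(=O)c1ccccc1Cl` gives 115 nM. Within these three numbers compound 3 stands second highest: the step of a 1.3-fold lower number from compound 1 to compound 3 (0.13 log units; within the scatter) is within the scatter, whereas the step of a 2.2-fold higher number from compound 2 to compound 3 (0.34 log units; beyond the scatter) is beyond it, so compound 2 sits apart from compounds 1 and 3, which cannot be ordered against each other.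

Compound 4 `CC(C)(C)N(NC(=O)c1cccc(Cl)c1Cl)C(=O)c1ccccc1Cl` differs from compound 3 by 2,3-dichlorophenyl in place of 4-chlorophenyl on a carbonyl carbon. Among the measured compounds shown here, no measured step adds a second chlorine to this ring. The step of a 1.3-fold lower number from compound 1 to compound 3 (0.13 log units; within the scatter) shows that moving the single chlorine across the ring leaves this assay unchanged within the scatter, and the step of a 3.0-fold lower number from compound 1 to compound 2 (0.47 log units; beyond the scatter) shows that exchanging chloro for methoxy gives a modest lowering. The change to compound 4 keeps chlorine and adds a second one at a different place on the same ring, so a step of at most modest size is expected in either direction, most likely none beyond the scatter.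

Compound 4 is therefore estimated at 130 nM, with a range from 45 nM to 380 nM, corresponding to an expected step of a 1.1-fold higher number from compound 3 to compound 4 (0.05 log units; within the scatter).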

Compound 4, half-maximal effective concentration: 9.33 nM
The estimate for compound 4 lay 14-fold (1.14 log units) above the measured number; the measured number lies below the stated range.
By their numbers in this assay, from the lowest: compound 4; then compound 2; then compounds 3 and 1 (each within the scatter of the next).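

Notes on the ring at this carbonyl carbon: in this assay, 2,3-dichlorophenyl is the first change on this ring to give a large step, with a 17-fold lower number from compound 1 to compound 4 (1.22 log units; beyond the scatter) on adding one chloro in place of hydrogen and a 12-fold lower number from compound 3 to compound 4 (1.09 log units; beyond the scatter) on the exchange for 4-chlorophenyl. Moving the single chlorine had stayed within the scatter (a 1.3-fold lower number from compound 1 to compound 3 (0.13 log units; within the scatter)), so the number of chlorines on this ring, or this particular pair of places, matters here in a way that the earlier compounds did not reveal. The exchange for 3-methoxyphenyl also lies beyond the scatter (a 5.6-fold lower number from compound 2 to compound 4 (0.75 log units; beyond the scatter)), which leaves compound 4 with the lowest number of the four, and nothing at hand gives a reason for the size of these steps.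

Going by these compounds, it remains open whether this lowering is particular to chlorine or would also follow from a methyl, a trifluoromethyl or a second methoxy on the same ring. On these data alone, it is also open whether 2,3-dichlorophenyl would give a step of similar size if the tert-butyl group on the shared core were exchanged for a longer chain.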